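The source may report more compounds than this note shows. Statements on the series, on what has been measured and on what is new or still open speak of the compounds shown alone.

Compound 1 `CC1CCCC(Nc2ncnc3c2nnn3Cc2ccccc2)C1` gives 770 nM in an assay on cell membranes for binding affinity to adenosine receptor A1 (Bos taurus), read by radioligand binding; on this read-out lower numbers stand for stronger inhibition and higher numbers for weaker inhibition.
Compound 2 `O=[N+]([O-])c1cccc(Nc2ncnc3c2nnn3Cc2ccccc2)c1` gives 443 nM in this assay.

Compound 2 has the lower of the two numbers, yet its gap to compound 1 lies within the scatter, so the two cannot be ranked. Compound 3 `Clc1cccc(Nc2ncnc3c2nnn3Cc2ccccc2)c1` differs from compound 2 by chloro in place of nitro on an aromatic carbon. For the measured compounds named here, no measured pair shows this exchange, so nothing observed tells its direction; a step no larger than the scatter is expected in this assay, in either direction. Compound 3 is expected to give about 350 nM, with a likely range from 120 nM to 1000 nM. That estimate amounts to an expected step of a 1.3-fold lower number from compound 2 to compound 3 (0.10 log units; within the scatter).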

Compound 3, inhibition constant: 463 nM
Beside the measured number, compound 3's estimate is 1.3-fold (0.12 log units) below it; the measured number falls inside the stated range.
By their numbers in this assay, from the lowest: compounds 2, 3 and 1 (each within the scatter of the next).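

In this assay, chloro in place of nitro on the aromatic carbon gives a 1.0-fold higher number from compound 2 to compound 3 (0.02 log units; within the scatter), so the two groups cannot be told apart at this place. Putting 3-chlorophenyl in place of 3-methylcyclohexyl on the nitrogen gives a 1.7-fold lower number from compound 1 to compound 3 (0.22 log units; within the scatter), so this larger exchange cannot be ranked either. No measurement at hand offers a reason for these results. From the compounds shown here alone, whether an amine, a carboxylic acid or a methoxy group at this aromatic carbon would shift the number beyond the scatter remains open.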